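The source may hold more compounds than are shown below. What is called first, only, known or untested is meant among the compounds shown, and "the series" means these compounds.

Of the compounds shown here, two have been measured in an assay on Huh-7 cells for agonist activity at Bile acid receptor (Homo sapiens), read by a luciferase reporter; on this read-out lower numbers stand for an effect already at smaller amounts and higher numbers for an effect only at larger amounts of compound. Compound 1 `CC(C)c1onc(-c2c(Cl)cccc2Cl)c1COc1ccc(-c2nc3ccc(C(=O)O)cc3n2CC2CCCCC2)c(F)c1` gives 7.8 nM in this assay. Among the measured compounds shown here, compound 2 `CCn1c(-c2ccc(OCc3c(-c4c(Cl)cccc4Cl)noc3C(C)C)cc2)nc2ccc(C(=O)O)cc21` gives 2.31 nM, the lowest of the two numbers; the only other number, that of compound 1, is higher by a margin beyond the usual scatter. For the measured compounds named here, no single-point step joins compound 1 and compound 2, so their two values show only that compound 2 acts at smaller amounts. The next compound is compound 3 `CC(C)c1onc(-c2c(Cl)cccc2Cl)c1COc1ccc(-c2nc3ccc(C(=O)O)cc3n2C2CCCCCC2)cc1`, which is compound 2 with cycloheptyl in place of ethyl on an aromatic nitrogen. Going by the values given here, nothing among the measured pairs tells how this assay responds to such an exchange on that nitrogen, so the expectation rests on compound 2 alone. For compound 3 the expected step is a 2.2-fold higher number from compound 2 to compound 3 (0.34 log units; beyond the scatter), a modest move toward a higher number that may well remain within the scatter. The estimate for compound 3 in this assay is 5 nM, within a range from 1.5 nM to 20 nM.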

Compound 3, half-maximal effective concentration: 14.8 nM
Compound 3: the middle estimate sits 3.0-fold (0.47 log units) below what was measured, and the stated range covers the measured number.
By their numbers in this assay, from the lowest: compound 2; then compounds 1 and 3 (each within the scatter of the next).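

Among the compounds shown here, this is the first single-point step in this assay, and it shows that the number responds to what the aromatic nitrogen carries: cycloheptyl in place of ethyl gives a 6.4-fold higher number from compound 2 to compound 3 (0.81 log units; beyond the scatter). Neither group carries a hydrogen-bond donor, a hydrogen-bond acceptor or a net charge, so the step comes with a change in carbon count and the arrival of a seven-membered non-aromatic ring, without any change in those counted features. Nothing available gives a reason for this step.

A single step cannot separate the effect of the ring from that of the added carbon, and a straight butyl chain or a cyclopentyl ring on that nitrogen would speak to this. As far as these compounds go, it also remains open how the assay would respond to a group there that bears a hydroxyl or an amine.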